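A few compounds are considered here, and "the series" means these few. Any claim that something is new, unique, unknown or untested is made for them only; others in the source may bear on it.

Compound 2 `Cc1c(Cl)cccc1N1C(=N)S/C(=C\c2ccc(OCc3ccccc3)cc2)C1=O` stands highest of the two compounds measured in an ADME assay on RAW264.7 cells (Mus musculus) for cytotoxicity, read by MTT assay, with a stated time of 48 h, tested at 50 uM (a higher number here means more inhibition at the concentration tested (going by the name of the read-out), a lower number less inhibition), where compound 2 gives 59.7%. Its nearest neighbour is compound 1 `N=C1S/C(=C\c2ccc(OCc3ccccc3)cc2)C(=O)N1c1ccc(Cl)cc1`, which in this assay gives 16.4%. Within the data shown here, the single measured step between them, a number 43.3 percentage points higher from compound 1 to compound 2 (beyond the scatter), replaces the 4-chlorophenyl with the 3-chloro-2-methylphenyl on the amide-type nitrogen in the ring, and it is the only guide to how this position behaves.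

Compound 3 `N=C1S/C(=C\c2ccc(OCc3ccccc3)cc2)C(=O)N1c1ncccn1` changes the same position again: pyrimidin-2-yl in place of 3-chloro-2-methylphenyl on an amide-type nitrogen in a ring. This step bears a resemblance to the measured one in that the group on the amide-type nitrogen in the ring is exchanged, and there the change was large, as shown by a number 43.3 percentage points higher from compound 1 to compound 2 (beyond the scatter). Among the measured compounds shown here, no measured compound carries a pyrimidin-2-yl or any group with hydrogen-bond acceptors at this place, so the direction cannot be read from the data. Given that compound 1 lies far lower than compound 2, the estimate for compound 3 in this assay is set between them and is expected to be 30%, with a range from 5% to 65%. The expected step of a number 29.7 percentage points lower from compound 2 to compound 3 (beyond the scatter) is therefore downward, but with wide uncertainty.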

Compound 3, a percentage reported as inhibition, at one concentration (the size of the read-out at that concentration, not a potency): 26.6%
Compound 3: middle estimate off by 3.4 percentage points, on the high side, within the range that was stated.
By their numbers in this assay, from the lowest: compound 1; then compound 3; then compound 2.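

Within this assay, exchanging the 3-chloro-2-methylphenyl for pyrimidin-2-yl gives a number 33.1 percentage points lower from compound 2 to compound 3 (beyond the scatter), so the high reading of compound 2 does not carry over to every six-membered aromatic ring at this place on the amide-type nitrogen. Set against the 4-chlorophenyl, the same pyrimidin-2-yl gives a number 10.2 percentage points higher from compound 1 to compound 3 (beyond the scatter), which places the new group between the two chlorine-bearing phenyl groups and shows that a chlorine on the ring does not by itself set the order, since compound 1 has one and stands lowest while compound 3 has none and stands above it. No measurement is available that explains these differences.

All three groups here are six-membered aromatic rings, so the compounds shown leave open how a plain phenyl, a phenyl with only the methyl or only the chlorine, or an open chain such as ethyl would read at this place. They also do not tell whether the large gap between compound 1 and compound 2 belongs to the methyl, to where the chlorine sits, or to both together.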